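Notes on replacing the chain amine with a benzamide

The source may hold more compounds than are shown below. What is called first, only, known or untested is meant among the compounds shown, and "the series" means these compounds.

Measured so far in a functional assay on MCF7 cells (Homo sapiens) for cytotoxicity, read by MTT assay, with a stated time of 72 h; on this read-out lower numbers stand for stronger inhibition and higher numbers for weaker inhibition:
- compound 2 `NCCNc1c(C(=O)NCc2ccc(F)cc2)nc(Br)c2cccnc12` gives 6000 nM
- compound 3 `N[C@H]1CC[C@H](Nc2c(C(=O)NCc3ccc(F)cc3)nc(Br)c3cccnc23)CC1` gives 2000 nM
- compound 1 `C[C@@H](Nc1c(C(=O)NCc2ccc(F)cc2)nc(Br)c2cccnc12)c1ccccc1` stands at "not determined" (no result reported) in this assay

On the numbers shown, compound 2 stands at the higher of the two values; the only neighbour, compound 3, sits lower by a 3.0-fold lower number from compound 2 to compound 3 (0.48 log units; beyond the scatter), a modest step that lies beyond the scatter. Compound 1 contributes nothing here.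

Compound 4 `O=C(NCCCNc1c(C(=O)NCc2ccc(F)cc2)nc(Br)c2cccnc12)c1ccccc1` differs from compound 2 by benzamidomethyl in place of amino on a saturated chain carbon, two bonds along the chain from a nitrogen on an aromatic ring. Among the measured compounds shown here, no measured step bears directly on this change: the single step, a 3.0-fold lower number from compound 2 to compound 3 (0.48 log units; beyond the scatter), keeps the amino group in place and alters only the saturated chain carrying it, whereas here the amino group itself leaves and a benzamidomethyl enters. For the measured compounds named here, the series therefore gives no measured precedent for what a capped, longer chain does in this assay, and no direction can be read from it.

With nothing to lean on, the working assumption is that compound 4 is expected to stay near compound 2, with a step of a 1.2-fold lower number from compound 2 to compound 4 (0.08 log units; within the scatter) not expected to exceed the scatter. Compound 4 is estimated at 5000 nM, with a range from 1500 nM to 16000 nM.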

Compound 4, half-maximal inhibitory concentration: 2000 nM
Estimate against measurement, compound 4: 2.5-fold (0.40 log units) above; measured number inside the range.
By their numbers in this assay, from the lowest: compounds 3 and 4 (each within the scatter of the next); then compound 2.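

In this assay, the position tolerates loss of the free amino group: a 3.0-fold lower number from compound 2 to compound 4 (0.48 log units; beyond the scatter) comes with benzamidomethyl in place of amino on a saturated chain carbon, two bonds along the chain from a nitrogen on an aromatic ring. The earlier numbers both came from compounds that keep the amino group, whereas compound 3 at 2000 nM now has company in compound 4 at 2000 nM, so a lower number in this assay is reached with or without that group. No measurement on hand offers an explanation for this step.

The change from compound 2 bundles a longer chain with a benzamide cap, so the compounds shown do not separate the contribution of each part; the free primary amine on the same longer chain, or an acetamide in place of the benzamide, would pull the two apart. Also open, going by these compounds, is whether the cap itself can vary, for instance with a carboxylic acid at the chain end or a fluorine on the benzamide ring.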